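The source may report more compounds than this note shows. Statements on the series, on what has been measured and on what is new or still open speak of the compounds shown alone.

Measured so far:
compound 1, `CCc1cc2oc(=O)n(CCC(=O)O)c2cc1Cl`; in an assay on HEK293 cells for inhibition of kynurenine 3-monooxygenase (Homo sapiens), read by LC-MS, with a stated time of 20 h (on this read-out higher numbers stand for weaker inhibition and lower numbers for stronger inhibition), compound 1 gives 316 nM
compound 2, `CC(C)Cc1cc2oc(=O)n(CCC(=O)O)c2cc1Cl`; in this assay compound 2 gives 794 nM

Among the measured compounds shown here, compound 2 has the higher of the two numbers, so it is the weaker inhibitor of the pair, and the only measured step, a 2.5-fold higher number from compound 1 to compound 2 (0.40 log units; beyond the scatter), shows that enlarging the side group on the shared core weakened inhibition. Compound 3, `O=C(O)CCn1c(=O)oc2cc(OCc3ccccn3)c(Cl)cc21`, is the next step: (pyridin-2-yl)methoxy in place of isobutyl on an aromatic carbon. For the measured compounds named here, no measured step tests an ether of this kind, so only the direction of the earlier step offers guidance. Compound 3 is therefore expected to stay close to compound 2, with a step of a 1.0-fold higher number from compound 2 to compound 3 (0.00 log units; within the scatter), at about 800 nM (range 200 nM to 3200 nM).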

Compound 3, half-maximal inhibitory concentration: 5010 nM
Compound 3: the middle estimate sits 6.3-fold (0.80 log units) below what was measured, and the stated range ends below it.
By their numbers in this assay, from the lowest: compound 1; then compound 2; then compound 3.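

At this position, on an aromatic carbon ortho to a chloro group, (pyridin-2-yl)methoxy weakens inhibition in this assay well beyond the scatter, with a 6.3-fold higher number from compound 2 to compound 3 (0.80 log units; beyond the scatter) and a 16-fold higher number from compound 1 to compound 3 (1.20 log units; beyond the scatter). Across these three compounds, the number rises as the group grows from ethyl through isobutyl to (pyridin-2-yl)methoxy, and none goes against this order. Nothing given here explains the loss. The compounds shown leave open whether the larger size, the oxygen link or the pyridine ring matters most. A plain methoxy or a benzyloxy group at this position could help separate these.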